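Chloro for Methoxy on the Arylpiperazine of Compound 2

The compounds below may be only part of what the source reports. "The series", "measured", "known", "first", "only" and "open" are said of these compounds alone.

Two compounds share a furoyl-piperazine unit attached to a pyridazinone core and an arylpiperazine on the other side. Compound 1 `COc1ccccc1N1CCN(CCn2ncc(N3CCN(C(=O)c4ccco4)CC3)c(Cl)c2=O)CC1` carries a two-carbon linker; in an assay on cell membranes for binding affinity to Adrenergic receptor alpha-1 (Rattus norvegicus), read by radioligand binding (on this read-out higher numbers stand for weaker inhibition and lower numbers for stronger inhibition), compound 1 gives 33 nM. Compound 2 `COc1ccccc1N1CCN(CCCCn2nc(N3CCN(C(=O)c4ccco4)CC3)ccc2=O)CC1` carries a four-carbon linker and the same 2-methoxyphenyl group; in this assay compound 2 gives 180 nM, the highest of the two numbers, while compound 1 shows a lower number, and the difference between these two values is beyond the usual scatter.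

Compound 3 `O=C(c1ccco1)N1CCN(c2ccc(=O)n(CCCCN3CCN(c4ccccc4Cl)CC3)n2)CC1` keeps the four-carbon linker of compound 2 and differs in one place: chloro in place of methoxy on an aromatic carbon, so that 2-methoxyphenyl becomes 2-chlorophenyl. Going by the values given here, no measured pair in this set shows this exchange, so the account rests on the two numbers alone. Compound 3 is expected to give a somewhat higher number than compound 2, a step of a 1.8-fold higher number from compound 2 to compound 3 (0.25 log units; within the scatter) that may still fall within the scatter. For compound 3 the estimate in this assay is 320 nM, with a range from 80 nM to 1300 nM.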

Compound 3, inhibition constant: 7.9 nM
Compound 3: the middle estimate sits 41-fold (1.61 log units) above what was measured; measured number outside the range, below it.
By their numbers in this assay, from the lowest: compound 3; then compound 1; then compound 2.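

In this assay, the exchange of methoxy for chloro on an aromatic carbon ortho to a large group gives a 23-fold lower number from compound 2 to compound 3 (1.36 log units; beyond the scatter), a large step beyond the scatter, with the four-carbon linker and the furoyl-piperazine side left unchanged. This position on the arylpiperazine is therefore far from silent: a single group, on its own, moves the number strongly, which the earlier pair could not show since compound 1 and compound 2 differ in more than one place. The change itself is small in count, with the two heavy atoms and one hydrogen-bond acceptor of methoxy giving way to one chlorine and no acceptor, and no ring or net charge involved. Nothing measured here bears on what lies behind this step.

Going by these compounds alone, since 2-methoxyphenyl to 2-chlorophenyl appears in only this one pair, whether the exchange gives a similar step with a two-carbon linker remains open. On these data alone, how a fluoro, a bromo or a methyl group would read on the same aromatic carbon, or an unsubstituted phenyl ring in its place, also remains open.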